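Methyl in place of oxolan-2-yl: a clearance estimate

The source may hold more compounds than are shown below. What is called first, only, known or untested is meant among the compounds shown, and "the series" means these compounds.

Compound 1 `Cc1cc(C)c(CN2CCc3c(Cl)cc([C@H](CO)[C@H]4CCCO4)c(Cl)c3C2=O)c(=O)[nH]1` is the reference of this account. Among the measured compounds shown here, in an ADME assay on microsomes from liver (Homo sapiens) for metabolic stability, read by LC-MS, using NADPH, with stated times of 10 min and 45 min, tested at 1 uM (a higher number here means faster removal of the compound, a lower number slower removal), compound 1 gives 51.6 uL/min, the only single number so far, with one further entry that carries no number. Compound 2 `Cc1cc(C)c(CN2CCc3c(Cl)cc(C(CO)c4ccon4)c(Cl)c3C2=O)c(=O)[nH]1` has repeated readings: in this assay compound 2 gives 22.7 uL/min; 21.2 uL/min (2 entries), the repeated readings being shown by the several entries of compound 2 in this assay, 22.7 uL/min; 21.2 uL/min (2 entries).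

The step in question leads to compound 3 `Cc1cc(C)c(CN2CCc3c(Cl)cc([C@@H](C)CO)c(Cl)c3C2=O)c(=O)[nH]1`, which differs from compound 1 as follows: methyl in place of oxolan-2-yl on a saturated chain carbon bound to an aromatic carbon and a saturated chain carbon. For the measured compounds named here, no measured pair in this set reports a change of this kind, so the direction of the step rests on expectation alone. The author expects a modest fall in this assay, close to the edge of the usual scatter, for compound 3 relative to compound 1 a 1.7-fold lower number from compound 1 to compound 3 (0.24 log units; within the scatter). For compound 3 the estimated value in this assay is 30 uL/min, expected to lie between 12 uL/min and 75 uL/min.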

Compound 3, intrinsic clearance in a liver preparation (reported as CLH), per the amount of preparation that the assay uses: 12.4 uL/min
The estimate for compound 3 lay 2.4-fold (0.38 log units) above the measured number; the range from low to high includes it.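

In this assay, among the compounds shown here, methyl in place of oxolan-2-yl on a saturated chain carbon bound to an aromatic carbon and a saturated chain carbon gives a 4.2-fold lower number from compound 1 to compound 3 (0.62 log units; beyond the scatter), the first measured step at this position. The position therefore responds to the group it carries: here, a single carbon in place of a ring of five heavy atoms goes with slower removal, though one step establishes no pattern. The size of this step can be set against the only repeated readings shown, which come from a compound outside the step: the several entries of compound 2 in this assay, 22.7 uL/min; 21.2 uL/min (2 entries)

The compounds shown do not separate the loss of the ring from the loss of its oxygen. They also leave open how an ethyl group, a longer chain or an amine would behave at this position.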